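Working notes on the step from compound 3 to compound 4

The source may hold more compounds than are shown below. What is called first, only, known or untested is meant among the compounds shown, and "the series" means these compounds.

Measured compounds:
compound 1 `CCN(CC)S(=O)(=O)c1ccc(NC(=O)c2ccccc2)c2ccccc12` — > 30000 nM
compound 2 `O=C(Nc1ccc(S(=O)(=O)N2CCCCC2)c2ccccc12)c1ccccc1` — > 30000 nM
compound 3 `CC(=O)N1CCC(NS(=O)(=O)c2ccc(NC(=O)c3ccccc3C)c3ccccc23)CC1` — 6.7 nM

In an assay on L1.2 cells for binding affinity to C-C chemokine receptor type 8 (Homo sapiens) (on this read-out lower numbers stand for stronger inhibition and higher numbers for weaker inhibition), compound 1 gives > 30000 nM, which is a limit of the assay and not a number. Compound 2 gives > 30000 nM, again a limit only. Among the measured compounds shown here, compound 3 gives 6.7 nM, the single number among the three. The step that the two limits leave unreadable from compound 1 to compound 2 is therefore unreadable, both values sitting at the limit of > 30000 nM in this assay, at which 2 of the 3 values shown sit.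

Compound 4 `Cc1ccccc1C(=O)Nc1ccc(S(=O)(=O)NC2CCN(C(=O)N3CCCC3)CC2)c2ccccc12` differs from compound 3 by pyrrolidin-1-yl in place of methyl on a carbonyl carbon, the change reading acetyl to (pyrrolidin-1-yl)carbonyl one bond further out. For the measured compounds named here, no measured step touches this carbonyl carbon, and the one measured step gives no size at all. For compound 4 a step of a 1.2-fold higher number from compound 3 to compound 4 (0.08 log units; within the scatter) within the scatter is expected. The estimate for compound 4 is 8 nM, with a range from 2.5 nM to 30 nM.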

Compound 4, inhibition constant: 1.1 nM
Estimate against measurement, compound 4: 7.3-fold (0.86 log units) above; the measured number lies below the stated range.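

On the carbonyl carbon whose other neighbour is the amide-type ring nitrogen, pyrrolidin-1-yl in place of methyl gives, in this assay, a 6.1-fold lower number from compound 3 to compound 4 (0.78 log units; beyond the scatter). Among the compounds shown here, this is the first readable step, and it shows that this carbonyl carbon accepts a much larger group with a gain in binding. No measurement shown gives a cause for this step.

Going by these compounds, whether the gain depends on the ring remains open, and an open-chain diethylamino group on the same carbonyl carbon would test this. On these data alone, how a methoxy group or a morpholine ring would behave there also remains open.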